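Thiophen-3-yl in place of pyridin-3-yl: an expected gain

The source may hold more compounds than are shown below. What is called first, only, known or untested is meant among the compounds shown, and "the series" means these compounds.

Measured compounds in a functional assay on thoracic aorta for inhibition of Voltage-gated L-type calcium channel (Rattus norvegicus); a lower number here means a stronger inhibitor, a higher number a weaker inhibitor:
compound 1 `CC1=NC(C)=C(C(=O)O)C(c2cccc(Br)c2)/C1=C(\O)OC/C=C/c1ccccc1` gives 10 nM
compound 2 `CC1=NC(C)=C(C(=O)O)C(c2cccc(I)c2)/C1=C(\O)OC/C=C/c1ccccc1` gives 13 nM
compound 3 `CC1=NC(C)=C(C(=O)O)C(c2cccnc2)/C1=C(\O)OC/C=C/c1ccccc1` gives 190 nM

Compound 3 stands at the highest number of the three. Its nearest neighbour is compound 2, and the step of a 15-fold higher number from compound 2 to compound 3 (1.16 log units; beyond the scatter) lies beyond the scatter; the step of a 19-fold higher number from compound 1 to compound 3 (1.28 log units; beyond the scatter) is larger still. Compound 1 and compound 2, which carry 3-bromophenyl and 3-iodophenyl on the saturated ring carbon, sit within the scatter of each other, as the step of a 1.3-fold higher number from compound 1 to compound 2 (0.11 log units; within the scatter) shows.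

Compound 4 `CC1=NC(C)=C(C(=O)O)C(c2ccsc2)/C1=C(\O)OC/C=C/c1ccccc1` has not yet been measured. It differs from compound 3 in one place: thiophen-3-yl in place of pyridin-3-yl on a saturated ring carbon. Among the compounds with values here, no measured step exchanges one heteroaromatic ring for another, so the two large steps from the halophenyl compounds to compound 3 are the only guide. They show that leaving pyridin-3-yl on that carbon has, in both measured cases, gone with a much lower number. Going by these compounds, whether a five-membered ring with a sulfur atom recovers all of that is unknown, so the expectation is a step towards a lower number, but a partial one: for compound 4 the expected step is a 3.8-fold lower number from compound 3 to compound 4 (0.58 log units; beyond the scatter), with a wide range. Compound 4 is therefore estimated at 50 nM, between 12 nM and 200 nM.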

Compound 4, half-maximal inhibitory concentration: 44 nM
Beside the measured number, compound 4's estimate is 1.1-fold (0.06 log units) above it; low and high end bracket the measured number.
By their numbers in this assay, from the lowest: compounds 1 and 2 (each within the scatter of the next); then compound 4; then compound 3.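

In this assay, the step of a 4.3-fold lower number from compound 3 to compound 4 (0.64 log units; beyond the scatter) shows that the saturated ring carbon distinguishes between two heteroaromatic rings, each with 1 hetero atom, so the large losses seen earlier with pyridin-3-yl do not extend in full to every such ring. The halophenyl compounds still keep a lead beyond the scatter, with a 4.4-fold higher number from compound 1 to compound 4 (0.64 log units; beyond the scatter) and a 3.4-fold higher number from compound 2 to compound 4 (0.53 log units; beyond the scatter), so this position now gives three levels: 3-bromophenyl and 3-iodophenyl, then thiophen-3-yl, then pyridin-3-yl. Nothing available explains this order, and no outside measurement bears on it.

Ring size and the hetero atom change together in this exchange, so the compounds shown cannot separate the part played by the five-membered ring from that played by sulfur in place of nitrogen; furan-3-yl, with oxygen in the five-membered ring, or thiophen-2-yl, attached through the other ring carbon, would bear on that question. Going by these compounds, it also remains open how much of the lead of the halophenyl compounds belongs to the halogen, which unsubstituted phenyl on the same carbon would address.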